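Difluoromethyl for trifluoromethyl on two related cores

The compounds below may be only part of what the source reports. "The series", "measured", "known", "first", "only" and "open" are said of these compounds alone.

The study compares four compounds in a physicochemical assay for solubility; on this read-out lower numbers stand for lower solubility and higher numbers for higher solubility. Compound 1 `C[C@@H]1CN(c2c(C#N)c(C(F)(F)F)nn2-c2ccc(S(C)(=O)=O)cn2)[C@H](C)CO1` carries a trifluoromethyl group and a pyridine-type ring bearing a methylsulfonyl group; in this assay compound 1 gives > 200 ug/mL, which is a limit of the assay rather than a number. Compound 3 `C[C@@H]1CN(c2c(C#N)c(C(F)F)nn2-c2ccc(S(C)(=O)=O)cn2)[C@H](C)CO1` differs from compound 1 by hydrogen in place of fluoro on a saturated chain carbon bound to an aromatic carbon and two fluorine atoms. In this assay compound 3 also gives > 200 ug/mL, again a limit of the assay. Because both values sit at the limit of > 200 ug/mL in this assay, at which 2 of the 3 values shown sit, the change from compound 1 to compound 3 is recorded as a step that the two limits leave unreadable from compound 1 to compound 3.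

Compound 2 `C[C@@H]1CN(c2c(C#N)c(C(F)(F)F)nn2-c2ccc(S(C)(=O)=O)cc2)[C@H](C)CO1` shares the substituted pyrazole portion but has a different aryl ring; the difference between the two cores is not broken down here. In this assay compound 2 gives "not determined" (no result reported).

Compound 4 `C[C@@H]1CN(c2c(C#N)c(C(F)F)nn2-c2ccc(S(C)(=O)=O)cc2)[C@H](C)CO1` stands to compound 2 as compound 3 stands to compound 1: the change is hydrogen in place of fluoro on a saturated chain carbon bound to an aromatic carbon and two fluorine atoms, the same kind of change as from compound 1 to compound 3. Since the measured pair only showed that both members lie at the limit, the size of this step cannot be read from them, and compound 2 itself has no value to build on. Compound 4 is therefore expected to give roughly 120 ug/mL, with a plausible range from 30 ug/mL to 250 ug/mL, resting only on the high solubility seen for compound 1 and compound 3 and the absence of any measured step for this core.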

Compound 4, solubility: 50 ug/mL
Compound 4: the middle estimate sits 2.4-fold (0.38 log units) above what was measured, and the stated range covers the measured number.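

In this assay, among the compounds shown here, compound 2 gives "not determined" (no result reported), so the value of 50 ug/mL for compound 4 yields no new step from compound 2 to compound 4. What the compounds shown leave open is how large the change from trifluoromethyl to difluoromethyl is on either core, as the pair of compound 1 and compound 3 rests on a limit: the limit of > 200 ug/mL in this assay, at which 2 of the 4 values shown sit.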